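Adding a methoxy to compound 2: an expectation

The compounds below may be only part of what the source reports. "The series", "measured", "known", "first", "only" and "open" are said of these compounds alone.

Measured in a functional assay for inhibition, with Rattus norvegicus as the target; on this read-out higher numbers stand for weaker inhibition and lower numbers for stronger inhibition:
- compound 1 `CCCCc1c(C)c(OC)c2ccccc2c1OC(C)=O` gives 200 nM
- compound 2 `CCCCc1cc(OC)c2ccccc2c1OC(C)=O` gives 440 nM
- compound 3 `CCCCc1cc(OC)c2ccc(OC)cc2c1OC(C)=O` gives 1380 nM

Compound 4 `CCCCc1cc(OC)c2c(OC)cccc2c1OC(C)=O` has not yet been measured.

Compound 2, at 440 nM in this assay, holds the middle place among the three numbers, with compound 1 nearest and compound 3 furthest. Compound 4 differs from compound 2 by one change, (methoxy in place of hydrogen on an aromatic carbon), which is methoxy in place of hydrogen on an aromatic carbon. Among the compounds with values here, the closest precedent is the same replacement on another aromatic carbon, seen as a 3.1-fold higher number from compound 2 to compound 3 (0.50 log units; beyond the scatter) in this assay and modest in size. Within the data shown here, the other measured step, a 2.2-fold higher number from compound 1 to compound 2 (0.34 log units; beyond the scatter), is a different replacement and shows only that modest steps occur. Among the measured compounds shown here, no measured compound carries a methoxy on this particular carbon, so the size remains uncertain. A modest move towards weaker inhibition is expected, and the estimated change is a 2.0-fold higher number from compound 2 to compound 4 (0.31 log units; beyond the scatter) in this read-out. Compound 4 is therefore estimated at 900 nM in this assay. The expected range for compound 4 runs from 350 nM to 2500 nM in this assay.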

Compound 4, half-maximal inhibitory concentration: 260 nM
Estimate against measurement, compound 4: 3.5-fold (0.54 log units) above; measured number below the stated range.
By their numbers in this assay, from the lowest: compounds 1, 4 and 2 (each within the scatter of the next, the first and the last beyond it); then compound 3.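

In this assay, methoxy in place of hydrogen on this aromatic carbon leaves compound 2 and compound 4 within the scatter of each other (a 1.7-fold lower number from compound 2 to compound 4 (0.23 log units; within the scatter)). Within the data shown here, the same replacement on another aromatic carbon moved the number beyond the scatter (a 3.1-fold higher number from compound 2 to compound 3 (0.50 log units; beyond the scatter)), so the outcome of this change depends on which aromatic carbon carries the methoxy, something the earlier compounds could not show. Nothing available here bears on the reason for this difference.

The compounds shown leave open whether a different group on this carbon, such as a hydroxyl, an amine or a fluorine, would also stay within the scatter of compound 2. They also leave open what this methoxy does when the methyl of compound 1 is present on the same core.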